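The source may report more compounds than this note shows. Statements on the series, on what has been measured and on what is new or still open speak of the compounds shown alone.

Measured in a functional assay on MCF7 cells (Homo sapiens) for cytotoxicity, read by sulforhodamine B assay, with a stated time of 48 h; on this read-out higher numbers stand for weaker inhibition and lower numbers for stronger inhibition:

- Compound 1 `Cc1ccccc1OS(=O)(=O)c1ccc(NC(=O)NCCCCl)cc1`: 27000 nM
- Compound 2 `O=C(NCCCCl)Nc1ccc(S(=O)(=O)Oc2ccc(O)cc2)cc1`: 51000 nM
- Compound 3 `Cc1ccccc1NS(=O)(=O)c1ccc(NC(=O)NCCCCl)cc1`: > 200000 nM

Compound 3 has no true number, and its value of > 200000 nM is only a limit of the assay.

Compound 4 `CCCc1ccccc1NS(=O)(=O)c1ccc(NC(=O)NCCCCl)cc1` carries ethyl in place of hydrogen on a saturated chain carbon bound to an aromatic carbon, turning 2-methylphenyl into 2-propylphenyl (ethyl in place of hydrogen on a saturated chain carbon bound to an aromatic carbon).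

Among the measured compounds shown here, no measured step makes this exact change. The closest is a change of the aromatic group alone, a 1.9-fold higher number from compound 1 to compound 2 (0.28 log units; within the scatter). The steps of an at least 7.4-fold higher number from compound 1 to compound 3 (0.86 log units; beyond the scatter) and an at least 3.9-fold higher number from compound 2 to compound 3 (0.59 log units; beyond the scatter) instead replace the oxygen link with the amino link, which compound 3 and compound 4 share. No step beyond the scatter is therefore expected in this assay, in either direction.

The expected step is a number no higher from compound 3 to compound 4 (the limit leaves the size open).

Compound 4 is estimated at 200000 nM, within an expected range of 70000 nM to 400000 nM.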

Compound 4, half-maximal inhibitory concentration: 35000 nM
Estimate against measurement, compound 4: 5.7-fold (0.76 log units) above; measured number outside the range, below it.
By their numbers in this assay, from the lowest: compounds 1, 4 and 2 (each within the scatter of the next). At a limit, above all of these: compound 3.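

In this assay, an at least 5.7-fold lower number from compound 3 to compound 4 (0.75 log units; beyond the scatter) comes from turning 2-methylphenyl into 2-propylphenyl, so the chain at this place can matter. The earlier compounds shown here tied a weak result to the amino link, yet compound 4 at 35000 nM keeps that link and still gives a measurable number. The true size of the step stays unknown because compound 3 stands only at a limit of the assay: the limit of > 200000 nM in this assay, at which 1 of the 4 values shown sits.

Whether the effect tracks chain length stays open, since 2-ethylphenyl and 2-butylphenyl are not among the compounds shown. Also open, going by these compounds, is whether a propyl chain would act the same way in the oxygen-linked compound 1.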